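A Formylfuran in Place of the Thiophene

The compounds below may be only part of what the source reports. "The series", "measured", "known", "first", "only" and "open" are said of these compounds alone.

Compound 1 `O=C1NCCC12CCN(c1c(Cl)cncc1-c1ccsc1)CC2` stands lowest of the three measured compounds in a functional assay on MV4-11 cells (Homo sapiens) for inhibition, read by resazurin assay, with a stated time of 72 h (on this read-out higher numbers stand for weaker inhibition of growth and lower numbers for stronger inhibition of growth), where compound 1 gives 190 nM. Compound 2 `O=Cc1ccc(-c2cncc(Cl)c2N2CCC3(CCNC3=O)CC2)s1` gives 750 nM and compound 3 `Cn1cccc1-c1cncc(Cl)c1N1CCC2(CCNC2=O)CC1` gives 900 nM; the steps of a 3.9-fold higher number from compound 1 to compound 2 (0.60 log units; beyond the scatter) and a 4.7-fold higher number from compound 1 to compound 3 (0.68 log units; beyond the scatter) both lie beyond the scatter, whereas the step of a 1.2-fold higher number from compound 2 to compound 3 (0.08 log units; within the scatter) stays within it. Compound 4 `O=Cc1cc(-c2cncc(Cl)c2N2CCC3(CCNC3=O)CC2)co1` differs from compound 1 by 5-formylfuran-3-yl in place of thiophen-3-yl on an aromatic carbon. Both measured replacements of the thiophen-3-yl group, including the 5-formylthiophen-2-yl case of compound 2, raised the number modestly, so a further modest rise in this assay is expected for compound 4. Compound 4 is therefore estimated at 600 nM, with a range from 250 nM to 1500 nM. The expected step for compound 4 is a 3.2-fold higher number from compound 1 to compound 4 (0.50 log units; beyond the scatter).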

Compound 4, concentration for 50% growth inhibition: 5150 nM
For compound 4 the middle estimate is 8.6-fold (0.93 log units) below the measured one, outside the stated range (above it).
By their numbers in this assay, from the lowest: compound 1; then compounds 2 and 3 (each within the scatter of the next); then compound 4.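

In this assay the 5-formylfuran-3-yl group on this aromatic carbon gives a large step, a 27-fold higher number from compound 1 to compound 4 (1.43 log units; beyond the scatter) and not the modest ones seen before at this position. Formyl-bearing rings do not behave alike here, since a 6.9-fold higher number from compound 2 to compound 4 (0.84 log units; beyond the scatter) separates two of them, and the new group also falls behind the 1-methyl-1H-pyrrol-2-yl group, with a 5.7-fold higher number from compound 3 to compound 4 (0.76 log units; beyond the scatter) as the step. No available evidence bears on this result. Still open, as far as these compounds go, is whether the furan ring or the formyl group drives the loss, and whether an aminomethyl group in place of formyl would return the number towards that of compound 1.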